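The source may report more compounds than this note shows. Statements on the series, on what has been measured and on what is new or still open speak of the compounds shown alone.

Compound 1 `Cc1n[nH]cc1-c1cccc2c1CCC2c1ncc[nH]1`: 634 nM
Compound 2 `c1cc(-c2ncco2)c2c(c1)C(c1ncc[nH]1)CC2`: 1390 nM

In a functional assay on CHO cells for agonist activity at Alpha-1D adrenergic receptor (Homo sapiens), read by FLIPR and calcium flux (a higher number here means that more compound is needed for the effect, a lower number that less compound is needed), compound 1 gives 634 nM and compound 2 gives 1390 nM, so compound 2 stands with the higher of the two numbers. Going by the values given here, the single measured step is a 2.2-fold higher number from compound 1 to compound 2 (0.34 log units; beyond the scatter). Compound 3 `c1cc(-c2cn[nH]c2)c2c(c1)C(c1ncc[nH]1)CC2` differs from compound 2 in one place: 1H-pyrazol-4-yl in place of 1,3-oxazol-2-yl on an aromatic carbon. That measured step bears on this change, since it ran the other way with a methylated pyrazolyl; reversing it points to a modest step toward a lower number. Compound 3 is therefore expected to show a 1.9-fold lower number from compound 2 to compound 3 (0.27 log units; within the scatter). In this assay compound 3 is estimated at 750 nM, within a range from 350 nM to 1600 nM.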

Compound 3, half-maximal effective concentration: 319 nM
The estimate for compound 3 lay 2.4-fold (0.37 log units) above the measured number; the whole stated range lies above it.
By their numbers in this assay, from the lowest: compounds 3 and 1 (each within the scatter of the next); then compound 2.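

In this assay, 1H-pyrazol-4-yl in place of 1,3-oxazol-2-yl on this aromatic carbon gives a 4.4-fold lower number from compound 2 to compound 3 (0.64 log units; beyond the scatter), showing that the unmethylated pyrazolyl also keeps the number below that of the oxazolyl. Hydrogen in place of methyl on the pyrazolyl gives a 2.0-fold lower number from compound 1 to compound 3 (0.30 log units; within the scatter), so the methyl makes no difference that can be told from the scatter. No measurement shown here accounts for the difference between the two rings. Going by these compounds, whether the hydrogen-bond donor of 1H-pyrazol-4-yl matters remains open, as does how an amine or a carboxylic acid would read on this carbon.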